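Methyl on the pendant phenyl of the methoxy coumarin pyrazole

A few compounds are considered here, and "the series" means these few. Any claim that something is new, unique, unknown or untested is made for them only; others in the source may bear on it.

The series shares one core carrying two ethyl esters, a coumarin and a phenyl ring on the pyrazole nitrogen. Compound 1 `CCOC(=O)c1c(-c2cc3ccccc3oc2=O)nn(-c2ccccc2)c1C(=O)OCC` gives 100000 nM in a functional assay on A549 cells (Homo sapiens) for cytotoxicity, read by MTT assay, with a stated time of 48 h; on this read-out lower numbers stand for stronger inhibition and higher numbers for weaker inhibition. Compound 2 `CCOC(=O)c1c(-c2cc3ccccc3oc2=O)nn(-c2cccc(C)c2)c1C(=O)OCC`, which carries a methyl on the phenyl ring, gives 52000 nM in this assay. Compound 3 `CCOC(=O)c1c(-c2cc3ccc(OC)cc3oc2=O)nn(-c2ccccc2)c1C(=O)OCC`, which carries a methoxy on the coumarin, gives 132000 nM in this assay. Compound 3 stands at the highest of the three numbers; compound 1 lies within the scatter of it, while compound 2 lies beyond the scatter from it.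

Compound 4 `CCOC(=O)c1c(-c2cc3ccc(OC)cc3oc2=O)nn(-c2cccc(C)c2)c1C(=O)OCC` is not yet measured. It differs from compound 3 in one place: methyl in place of hydrogen on an aromatic carbon. The same change has been measured once, as the step of a 1.9-fold lower number from compound 1 to compound 2 (0.28 log units; within the scatter), a shift that stays within the scatter. Going by the values given here, no step on the methoxy-bearing core has yet been measured, so the only bearing is that single step. Compound 4 is therefore expected to show a step of about a 1.9-fold lower number from compound 3 to compound 4 (0.28 log units; within the scatter), likely within the scatter, toward a lower number. The estimate for compound 4 in this assay is 70000 nM, with a range from 30000 nM to 160000 nM.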

Compound 4, half-maximal inhibitory concentration: 171000 nM
For compound 4 the middle estimate is 2.4-fold (0.39 log units) below the measured one; the measured number lies above the stated range.
By their numbers in this assay, from the lowest: compounds 2, 1, 3 and 4 (each within the scatter of the next, the first and the last beyond it).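

Going by these compounds alone, on the methoxy-bearing core, phenyl to 3-methylphenyl gives a 1.3-fold higher number from compound 3 to compound 4 (0.11 log units; within the scatter), so the lower number seen on the core of compound 1 does not recur here, and the two readings of this change cannot be told apart: the same change on two cores in this assay, a 1.9-fold lower number (0.28 log units; within the scatter) from compound 1 to compound 2 and a 1.3-fold higher number (0.11 log units; within the scatter) from compound 3 to compound 4, 2.5-fold (0.40 log units) apart, within the scatter of two such steps Methoxy in place of hydrogen, read on the 3-methylphenyl core, gives a 3.3-fold higher number from compound 2 to compound 4 (0.52 log units; beyond the scatter), the first step of this change beyond the scatter, yet it does not differ measurably from the same change on the phenyl core: the same change on two cores in this assay, a 1.3-fold higher number (0.12 log units; within the scatter) from compound 1 to compound 3 and a 3.3-fold higher number (0.52 log units; beyond the scatter) from compound 2 to compound 4, 2.5-fold (0.40 log units) apart, within the scatter of two such steps The four compounds therefore show no dependence of the methyl step on the methoxy, or of the methoxy step on the methyl, that stands clear of the scatter in this assay.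

The compounds shown leave open whether any group at this aromatic carbon moves the number beyond the scatter on both cores, for example an amine or a carboxylic acid in place of the methyl. They also leave open how the number responds at the two ethyl esters, for example with a carboxylic acid or an amide in place of either one.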